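Ester variation at the tertiary alcohol of the anilide core

The source may report more compounds than this note shows. Statements on the series, on what has been measured and on what is new or still open speak of the compounds shown alone.

Measured in a functional assay on MCF7 cells (Homo sapiens) for inhibition, read by MTT assay, with a stated time of 72 h; a higher number here means a weaker inhibitor, a lower number a stronger inhibitor:
compound 1, `O=C(OC1(C(=O)Nc2ccc([N+](=O)[O-])cc2)CCCCC1)c1ccc(C(F)(F)F)cc1`, gives 27.1 nM
compound 2, `O=COC1(C(=O)Nc2ccc([N+](=O)[O-])cc2)CCCCC1`, gives 35.4 nM

Compound 2 shows the higher of the two numbers, but the step of a 1.3-fold higher number from compound 1 to compound 2 (0.12 log units; within the scatter) lies within the scatter. Compound 3, `CCC(=O)OC1(C(=O)Nc2ccc([N+](=O)[O-])cc2)CCCCC1`, differs from compound 2 by ethyl in place of hydrogen on a carbonyl carbon. For the measured compounds named here, the only step bearing on this position is a 1.3-fold higher number from compound 1 to compound 2 (0.12 log units; within the scatter), where a much larger acyl change left the number within the scatter; no step beyond the scatter is therefore expected in this assay. Compound 3 is estimated at 30 nM (range 15 nM to 70 nM), an expected step of a 1.2-fold lower number from compound 2 to compound 3 (0.07 log units; within the scatter).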

Compound 3, half-maximal inhibitory concentration: 14.1 nM
For compound 3 the middle estimate is 2.1-fold (0.33 log units) above the measured one; measured number outside the range, below it.
By their numbers in this assay, from the lowest: compounds 3, 1 and 2 (each within the scatter of the next, the first and the last beyond it).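

Formyl to propanoyl is the first change at this acyl position to go beyond the scatter in this assay, with a 2.5-fold lower number from compound 2 to compound 3 (0.40 log units; beyond the scatter). Replacing the 4-(trifluoromethyl)phenyl group with ethyl stays within the scatter, with a 1.9-fold lower number from compound 1 to compound 3 (0.28 log units; within the scatter), so the ethyl and aryl esters are not separated, though only the ethyl ester is separated from the formate. Nothing available explains the size of the ethyl step.

From the compounds shown here alone, whether a longer chain such as butyl keeps the number near that of compound 3 remains open. So does the effect of an amine or carboxylic acid at the end of the acyl chain.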